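Changing the Amine Part of Compound 2

This account rests on a few compounds, and the source may have more. Where it says the series, first, only, none or still open, it means among the compounds named here.

Of the compounds shown here, three have been tested so far in a functional assay on LM7 cells (Homo sapiens) for antiproliferative activity, read by MTT assay, with a stated time of 72 h; a higher number here means a weaker inhibitor, a lower number a stronger inhibitor. Compound 1 `Cc1ccc2c(=O)c(CSC(=S)N3CCCCC3)coc2c1` gives 5100 nM in this assay. Compound 3 `O=c1c(SC(=S)N2CCCC2)coc2ccc(Cl)cc12` gives 24600 nM in this assay. Compound 2 `CCOC(=O)c1cc(=O)c2cc(CSC(=S)N(C(C)C)C(C)C)ccc2o1` is reported only as a limit of this assay, > 25000 nM, and the limit of > 25000 nM in this assay, at which 1 of the 3 values shown sits, marks where that value sits.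

Compound 4 `CCOC(=O)c1cc(=O)c2cc(CSC(=S)N(C)c3ccccc3)ccc2o1` has not yet been measured. It differs from compound 2 in a single place: methyl(phenyl)amino in place of diisopropylamino on a thiocarbonyl carbon. No measured pair of compounds shows a change of this kind, so there is no shown step to lean on. Compound 1 and compound 3 are both weak inhibitors in this assay, and compound 2 did not reach a number at all. The expectation for compound 4 is therefore a step of an at least 1.1-fold lower number from compound 2 to compound 4 (0.05 log units; that floor lies within the scatter) that stays within the usual scatter, with a real chance that the outcome is again a limit rather than a number. Compound 4 is estimated at 22000 nM, expected to fall between 6000 nM and 60000 nM.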

Compound 4, half-maximal inhibitory concentration: > 25000 nM
Compound 4 was reported as a limit; the forecaster's own chance of this, stated with the estimate: 50%; at least 1.1-fold (0.05 log units) between middle value and limit.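

Going by these compounds alone, compound 2 and compound 4 are both reported only as limits in this assay, so no step between them can be read: the limit of > 25000 nM in this assay, at which 2 of the 4 values shown sit. The compounds shown leave open whether methyl(phenyl)amino or diisopropylamino on a thiocarbonyl carbon gives the stronger inhibitor, and by how much.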